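From 4-Chlorobenzyl to 2-Bromobenzyl on the Ring Amine

A few compounds are considered here, and "the series" means these few. Any claim that something is new, unique, unknown or untested is made for them only; others in the source may bear on it.

Of the compounds shown here, two sharing one core have been measured in an assay on isolated protein for inhibition of Fatty-acid amide hydrolase 1 (Homo sapiens); on this read-out lower numbers stand for stronger inhibition and higher numbers for weaker inhibition. Compound 1 `CC(C)(C)CC(=O)N1CCC(CCCC(=O)c2ncco2)CC1` gives 90 nM. Compound 2 `O=C(CCCC1CCN(Cc2ccc(Cl)cc2)CC1)c1ncco1` gives 66 nM; of the two numbers this is the lower one, but the step of a 1.4-fold lower number from compound 1 to compound 2 (0.13 log units; within the scatter) lies within the scatter, so nothing separates them. Compound 3 `O=C(CCCC1CCN(Cc2ccccc2Br)CC1)c1ncco1` has not yet been measured and differs from compound 2 in one place: 2-bromophenyl in place of 4-chlorophenyl on a saturated chain carbon bound to an amine nitrogen in a ring. For the measured compounds named here, no measured step bears directly on this exchange of one halogenated benzyl group for another; the only step known, neopentylcarbonyl to 4-chlorobenzyl, was a 1.4-fold lower number from compound 1 to compound 2 (0.13 log units; within the scatter) and stayed within the scatter. With nothing pointing either way, the expected step is a 1.5-fold higher number from compound 2 to compound 3 (0.18 log units; within the scatter) in this assay, not beyond the scatter. Compound 3 is therefore estimated at 100 nM, with a range from 30 nM to 330 nM.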

Compound 3, half-maximal inhibitory concentration: 315 nM
For compound 3 the middle estimate is 3.2-fold (0.50 log units) below the measured one; measured number inside the range.
By their numbers in this assay, from the lowest: compounds 2 and 1 (each within the scatter of the next); then compound 3.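

In this assay the substituent on the ring amine nitrogen proves able to move the number: a 4.8-fold higher number from compound 2 to compound 3 (0.68 log units; beyond the scatter) lies beyond the scatter, although 4-chlorophenyl and 2-bromophenyl have equal heavy-atom counts and neither has a hydrogen-bond donor or acceptor. The 2-bromobenzyl group also separates from the neopentylcarbonyl group, with a 3.5-fold higher number from compound 1 to compound 3 (0.54 log units; beyond the scatter) again beyond the scatter, whereas the two earlier compounds could not be told apart. Nothing measured here accounts for this loss of inhibition.

The halogen and its place on the phenyl ring change together in this step, so the compounds shown do not tell which of the two matters. The 2-chlorobenzyl and 4-bromobenzyl groups would separate them, and the unsubstituted benzyl group would show what either halogen contributes.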